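The source may hold more compounds than are shown below. What is called first, only, known or untested is meant among the compounds shown, and "the series" means these compounds.

Measured compounds: compound 1 `C#CCNCc1cc2ccccc2n1C` gives 3830 nM in an assay on isolated protein for inhibition of Amine oxidase [flavin-containing] B (Rattus norvegicus); a higher number here means a weaker inhibitor, a lower number a stronger inhibitor; compound 2 `C#CCN(C)Cc1cc2cc(O)ccc2n1C` gives 820 nM in this assay.

Of the two numbers recorded, compound 2 holds the lower one, and its distance from compound 1 lies beyond the usual scatter of the assay. Compound 3 `C#CCN(C)Cc1cc2ccccc2n1C` is not yet measured. It differs from compound 2 in one place: hydrogen in place of hydroxy on an aromatic carbon. Within the data shown here, no measured pair shows the effect of this change on its own, so the size of the step cannot be read from the data. Compound 1, which also carries no hydroxy group, shows the higher of the two numbers, and compound 3 is therefore expected to move toward that value with an estimated step of a 2.4-fold higher number from compound 2 to compound 3 (0.39 log units; beyond the scatter) in this assay. The estimate for compound 3 in this assay is 2000 nM, with a range from 800 nM to 5000 nM.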

Compound 3, inhibition constant: 3 nM
Compound 3: middle estimate off by 670-fold (2.82 log units), on the high side; the measured number lies below the stated range.
By their numbers in this assay, from the lowest: compound 3; then compound 2; then compound 1.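

In this assay the change from hydroxy to hydrogen on this aromatic carbon gives a 270-fold lower number from compound 2 to compound 3 (2.44 log units; beyond the scatter) and so the hydroxy group is not needed for a low number in this series. Methyl in place of hydrogen on the amine nitrogen gives a 1300-fold lower number from compound 1 to compound 3 (3.11 log units; beyond the scatter) and this shows that, without the hydroxy group, the high number of compound 1 goes with the hydrogen on that nitrogen. No measurement at hand accounts for the size of either step.

The compounds shown leave open whether a methoxy group or a fluorine atom on this aromatic carbon would keep a number close to that of compound 3. They also leave open whether an ethyl group or a longer chain on the amine nitrogen could stand in for the methyl.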